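From dipropylamino to piperidin-1-yl: a cytotoxicity limit

The source may report more compounds than this note shows. Statements on the series, on what has been measured and on what is new or still open speak of the compounds shown alone.

Measured in an ADME assay on MT4 cells (Homo sapiens) for cytotoxicity, read by MTT assay, with a stated time of 4 days; on this read-out lower numbers stand for higher toxicity in this test and higher numbers for lower toxicity in this test:
- compound 1 `O=c1cc(Cc2c(F)cccc2F)nc(N2CCCCC2)[nH]1`: > 82000 nM
- compound 2 `CCN(CC)c1nc(Cc2c(F)cccc2F)c(C)c(=O)[nH]1`: > 81000 nM
- compound 3 `CCCN(CCC)c1nc(Cc2c(F)cccc2F)c(C)c(=O)[nH]1`: > 74000 nM

All three entries are limits and not numbers. Compound 3 stands at a limit of > 74000 nM, and the two other values are limits as well.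

The next compound is compound 4 `Cc1c(Cc2c(F)cccc2F)nc(N2CCCCC2)[nH]c1=O`, with piperidin-1-yl in place of dipropylamino on an aromatic carbon, between two ring nitrogen atoms: piperidin-1-yl in place of dipropylamino on an aromatic carbon.

Within the data shown here, the only measured step that bears on this change is a step that the two limits leave unreadable from compound 2 to compound 3, with dipropylamino in place of diethylamino, so it gives no size to carry over. Compound 1 also carries piperidin-1-yl, and it too gives only a limit, > 82000 nM. On this evidence, no step beyond the scatter is expected in this assay, and no direction can be assigned. The expected change is a step that the limit leaves unreadable from compound 3 to compound 4. The estimate for compound 4 is 78000 nM, with an expected range from 30000 nM to 100000 nM.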

Compound 4, half-maximal cytotoxic concentration: > 78000 nM
Compound 4: a limit, no number; the forecaster's own chance of this, stated with the estimate: 75%; the middle value sits exactly at the limit.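

In this assay, among these compounds, compound 4 gives > 78000 nM, a limit and not a number, and no step to compound 4 from compound 1, compound 2 or compound 3 can be read. The compounds shown leave open at what concentration any of the four becomes toxic to these cells.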